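Swapping chloro for fluoro on a saturated ring carbon

This account rests on a few compounds, and the source may have more. Where it says the series, first, only, none or still open, it means among the compounds named here.

The study concerns an ADME assay on IMR-90 cells (Homo sapiens) for cytotoxicity, read by CellTiter-Blue, with a stated time of 46 h; a higher number here means that more compound is needed for the effect, a lower number that less compound is needed. Among the compounds with values here, compound 1, `CC1(C)CCN(S(=O)(=O)c2ccc(NC(=O)c3ccc([N+](=O)[O-])o3)cc2)CC1`, is one of two compounds measured. In this assay compound 1 gives > 25000 nM, which is a limit of the assay rather than a number. Compound 2, `O=C(Nc1ccc(S(=O)(=O)N2CCC(Cl)CC2)cc1)c1ccc([N+](=O)[O-])o1`, carries 4-chloropiperidin-1-yl in place of 4,4-dimethylpiperidin-1-yl on a sulfonyl sulfur. In this assay compound 2 gives > 25000 nM, again a limit of the assay and not a number. The step that the two limits leave unreadable from compound 1 to compound 2 is therefore unreadable, because both values sit at the limit of > 25000 nM in this assay, at which 2 of the 2 values shown sit. Compound 2 thus stands where every measured compound stands: at the limit, with no number of its own.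

Compound 3, `O=C(Nc1ccc(S(=O)(=O)N2CCC(F)CC2)cc1)c1ccc([N+](=O)[O-])o1`, differs from compound 2 by fluoro in place of chloro on a saturated ring carbon. Within the data shown here, no measured step bears directly on this exchange, and the one measured step could not be read. With both values at the limit, the step expected for compound 3 is a step that the limit leaves unreadable from compound 2 to compound 3. Compound 3 is therefore estimated at 40000 nM, within a range from 20000 nM to 100000 nM, and is most likely to be reported as a limit as well.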

Compound 3, half-maximal effective concentration: > 25000 nM
Compound 3: a limit, no number; the forecaster's own chance of this, stated with the estimate: 85%; the middle value lies beyond the limit too.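

In this assay compound 3 gives > 25000 nM, a limit of the assay and not a number. Within the data shown here, no new step to compound 3 from compound 1 or compound 2 can be read, because all the values sit at the same limit: the limit of > 25000 nM in this assay, at which 3 of the 3 values shown sit. The compounds shown leave open whether fluoro in place of chloro changes the half-maximal effective concentration at all.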